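A few compounds are considered here, and "the series" means these few. Any claim that something is new, unique, unknown or untested is made for them only; others in the source may bear on it.

Measured so far in a functional assay on MDA-MB-435 cells (Homo sapiens) for inhibition, read by sulforhodamine B assay, with a stated time of 48 h; a lower number here means a stronger inhibitor of growth, a higher number a weaker inhibitor of growth:
compound 1 `Nc1cc(N)c2nc(-c3ccccc3)c(Oc3ccc(Cl)c(Cl)c3)nc2c1` gives 5010 nM
compound 2 `CCOC(=O)[C@H](CCC(=O)O)NC(=O)c1ccc(CNc2nc3cc(N)cc(N)c3nc2-c2ccccc2)cc1` gives 66100 nM
compound 3 `CCOC(=O)[C@H](CCC(=O)O)NC(=O)c1ccc(Sc2nc3cc(N)cc(N)c3nc2-c2ccccc2)cc1` gives 11200 nM

Within these three, compound 1 holds the lowest number in this assay. Compound 3 lies above it by a gap beyond the scatter, and compound 2 lies further above still, well beyond the scatter. No two of these compounds differ in a single place, so no step can be drawn between them; all that can be said is what the values show.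

Compound 4 `Nc1cc(N)c2nc(-c3ccccc3)c(NCc3ccc(F)cc3)nc2c1` is the next compound for this assay. Relative to compound 1 it carries (4-fluorobenzyl)amino in place of 3,4-dichlorophenoxy on an aromatic carbon. A direct neighbour in the shared core is thus replaced, the aryl ether giving way to a benzyl-type amine bearing a single fluorine.

Because compound 1 stands at 5010 nM and the other two members of the set sit above it, the expectation for compound 4 is a loss rather than a gain: a 3.0-fold higher number from compound 1 to compound 4 (0.48 log units; beyond the scatter) is the estimated step. On that basis compound 4 is estimated at 15000 nM in this assay, with a range from 5000 nM to 50000 nM.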

Compound 4, concentration for 50% growth inhibition: 2000 nM
The estimate for compound 4 lay 7.5-fold (0.88 log units) above the measured number, outside the stated range (below it).
By their numbers in this assay, from the lowest: compound 4; then compound 1; then compound 3; then compound 2.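

In this assay the exchange of 3,4-dichlorophenoxy for (4-fluorobenzyl)amino gives a 2.5-fold lower number from compound 1 to compound 4 (0.40 log units; beyond the scatter) and thus a modest step beyond the scatter, so this aromatic carbon next to the ring nitrogen and ortho to a phenyl group tolerates a change of both link and ring substituents without a rise in the number. The change is composite: the ether oxygen gives way to an amine with a carbon spacer, a hydrogen-bond donor enters, and two chlorines give way to one fluorine. No measurement here explains the step or assigns it to any one of these parts.

Which part carries the step remains open. A plain benzylamino, a 3,4-dichlorobenzylamino or a 4-fluorophenoxy group at this carbon would separate link from halogen pattern, and a 2-phenylethylamino chain would test the spacer length.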